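Swapping the spiro amine for a pyridylpiperazine

The source may report more compounds than this note shows. Statements on the series, on what has been measured and on what is new or still open speak of the compounds shown alone.

Compound 3 `COc1ccc2[nH]c(C(=O)N3CC(=O)N(Cc4ccccc4)[C@@H](CCN4CCC5(CC4)CC5)C3)cc2c1` carries a spiro amine on a short chain. In a physicochemical assay for solubility, read by spectrophotometry, in phosphate buffer, with a stated time of 2 h, at pH 7.4 (a lower number here means a less soluble compound, a higher number a more soluble compound), compound 3 gives > 25000 nM, which is a limit of the assay and not a number. Compound 1 `COc1ccc2[nH]c(C(=O)N3CC(=O)N(Cc4ccccc4)[C@@H](CN4CCC5(CC4)CC5)C3)cc2c1` gives 28200 nM in this assay, and compound 2 `COc1ccc2[nH]c(C(=O)N3CC(=O)N(Cc4ccccc4)[C@@H](CN4CCN(S(=O)(=O)c5ccccc5)CC4)C3)cc2c1` gives 16900 nM. For the measured compounds named here, the one directly related step, a step that the limit leaves unreadable from compound 1 to compound 3, cannot be sized because compound 3 sits at the limit of > 25000 nM in this assay, at which 1 of the 3 values shown sits. Compound 4 `COc1ccc2[nH]c(C(=O)N3CC(=O)N(Cc4ccccc4)[C@@H](CN4CCN(c5ccccn5)CC4)C3)cc2c1` differs from compound 3 by a group of 12 heavy atoms (9 carbon, 3 nitrogen; one six-membered non-aromatic ring with 2 hetero atoms, one six-membered aromatic ring with 1 hetero atom) in place of a group of 9 heavy atoms (8 carbon, 1 nitrogen; one three-membered non-aromatic ring of carbon only, one six-membered non-aromatic ring with 1 hetero atom), on a saturated chain carbon bound to a saturated ring carbon. Going by the values given here, no measured step matches this change, so the estimate for compound 4 is drawn from the spread of compounds 1 and 2, and the expected step of an at least 1.6-fold lower number from compound 3 to compound 4 (0.22 log units; that floor lies within the scatter) is small. Compound 4 is expected to give about 15000 nM, within 5000 nM to 30000 nM.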

Compound 4, solubility: 30200 nM
Estimate against measurement, compound 4: 2.0-fold (0.30 log units) below; the whole stated range lies below it.
By their numbers in this assay, from the lowest: compounds 2, 1 and 4 (each within the scatter of the next).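

In this assay, pyridin-2-yl in place of phenylsulfonyl on an amine nitrogen in a ring gives a 1.8-fold higher number from compound 2 to compound 4 (0.25 log units; within the scatter), and 4-(pyridin-2-yl)piperazin-1-yl in place of the spiro amine of compound 1 gives a 1.1-fold higher number from compound 1 to compound 4 (0.03 log units; within the scatter). Neither swap of the group on this saturated chain carbon gives a step beyond the scatter. Compound 3 stands at a limit, not a number, so its step to compound 4 cannot be read: the limit of > 25000 nM in this assay, at which 1 of the 4 values shown sits.

From the compounds shown here alone, whether a carboxylic acid on this carbon would give a step beyond the scatter stays open. So does the effect of a longer chain carrying 4-(pyridin-2-yl)piperazin-1-yl.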